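Adding a Bromo Group to an Inactive Cytotoxic Series

The source may report more compounds than this note shows. Statements on the series, on what has been measured and on what is new or still open speak of the compounds shown alone.

Compound 1, `C=C1C[C@]23C[C@@]1(O)CC[C@H]2c1cc(Br)c(O)c(C)c1[C@@H]3Cn1cc(-c2ccc(OC)cc2)nn1`: > 20000 nM
Compound 2, `C=C1C[C@]23C[C@@]1(O)CC[C@H]2c1ccc(O)c(C)c1[C@@H]3Cn1cc(-c2ccc(C)cc2)nn1`: > 20000 nM

Of the compounds shown here, two have been tested so far in a functional assay on SW480 cells (Homo sapiens) for cytotoxicity, read by MTT assay, with a stated time of 4 days; on this read-out lower numbers stand for stronger inhibition and higher numbers for weaker inhibition. In this assay compound 1 gives > 20000 nM, which is a limit of the assay and not a number. In this assay compound 2 likewise gives > 20000 nM, again a limit rather than a number. Compound 2 therefore stands at the ceiling of what this assay reports, with no measured inhibition in reach, and compound 1 sits at the same place: the limit of > 20000 nM in this assay, at which 2 of the 2 values shown sit.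

Compound 3, `C=C1C[C@]23C[C@@]1(O)CC[C@H]2c1cc(Br)c(O)c(C)c1[C@@H]3Cn1cc(-c2ccc(C)cc2)nn1`, differs from compound 2 in one respect: bromo in place of hydrogen on an aromatic carbon. Compound 1 also carries a bromo group and still shows no measurable effect, so the bromo group by itself has not pulled any compound into the measurable range. Among the compounds with values here, no step in this assay beyond the usual scatter is expected, and compound 3 is expected to move by a step that the limit leaves unreadable from compound 2 to compound 3. Compound 3 is estimated at 30000 nM, with a likely range from 15000 nM to 80000 nM, most probably reported only as a limit.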

Compound 3, half-maximal inhibitory concentration: > 20000 nM
Compound 3: a limit, no number; the forecaster's own chance of this, stated with the estimate: 85%; the middle value does not contradict the limit.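

Compound 1, compound 2 and compound 3 all give a limit and not a number in this assay, so no step between them can be read: the limit of > 20000 nM in this assay, at which 3 of the 3 values shown sit.

The compounds shown leave open whether bromo in place of hydrogen, or methyl in place of methoxy, changes cytotoxicity at all.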